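Diisopentylamino analogue in the benzamide sulfamate series

This account rests on a few compounds, and the source may have more. Where it says the series, first, only, none or still open, it means among the compounds named here.

Among the measured compounds shown here, compound 3 `CN(C)CCN(CCN(C)C)c1cccc(C(=O)N2CCc3ccc(OS(N)(=O)=O)cc3C2)c1` is the weakest of the three measured members: in an assay on HEK293 cells for inhibition of Steryl-sulfatase (Homo sapiens), tested at 1 uM (a lower number here means a weaker effect, a higher number a stronger effect of the compound at the concentration tested), compound 3 gives 17.1%, whereas compound 2 `CN(CCCN1CCCCC1)c1cccc(C(=O)N2CCc3ccc(OS(N)(=O)=O)cc3C2)c1` gives 30.6% and compound 1 `CCN(Cc1ccc(Br)cc1)c1cccc(C(=O)N2CCc3ccc(OS(N)(=O)=O)cc3C2)c1` gives 84.5%. Compound 4 `CC(C)CCN(CCC(C)C)c1cccc(C(=O)N2CCc3ccc(OS(N)(=O)=O)cc3C2)c1` differs from compound 3 in a single place: diisopentylamino in place of bis(2-(dimethylamino)ethyl)amino on an aromatic carbon. Compound 1 likewise carries a substituent without dimethylamino or piperidinyl arms, so two measured steps bear on this change. a number 67.4 percentage points lower from compound 1 to compound 3 (beyond the scatter) is the closer comparison and was large. a number 13.5 percentage points lower from compound 2 to compound 3 (beyond the scatter) was only modest. An upward step of substantial size is therefore expected for compound 4, namely a number 52.9 percentage points higher from compound 3 to compound 4 (beyond the scatter). Compound 4 is estimated at 70%, with a plausible range from 45% to 90%, given the uncertainty of a single comparison.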

Compound 4, a percentage reported as inhibition, at one concentration (the size of the read-out at that concentration, not a potency): 75.9%
Compound 4: middle estimate off by 5.9 percentage points, on the low side; the range from low to high includes it.
By their numbers in this assay, from the lowest: compound 3; then compound 2; then compounds 4 and 1 (each within the scatter of the next).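

In this assay, with 11 heavy atoms and no ring on either side of the change, replacing the nitrogen-bearing arms with diisopentylamino on this aromatic carbon gives a number 58.8 percentage points higher from compound 3 to compound 4 (beyond the scatter). The change from the piperidinyl-bearing chain is also large, with a number 45.3 percentage points higher from compound 2 to compound 4 (beyond the scatter), whereas a number 8.6 percentage points lower from compound 1 to compound 4 (within the scatter) shows that a 4-bromobenzyl group is not needed for a read-out at this level. Nothing available accounts for these steps.

Still open, on these data alone, is whether a shorter dipropylamino group would hold the read-out. Also open, as far as these compounds go, is what a single dimethylamino or carboxylic acid at the end of one isopentyl-length chain would do.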